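Ester alkyl variation and microsomal stability of the series

The source may hold more compounds than are shown below. What is called first, only, known or untested is meant among the compounds shown, and "the series" means these compounds.

Compound 2 `CCCCOC(=O)Cc1c(C)nc(CCCC)n(Cc2ccc(-c3ccccc3-c3noc(=O)[nH]3)cc2)c1=O` is one of two esters on the shared core with a measurement so far. In an ADME assay on microsomes from liver (Mus musculus) for metabolic stability, with a stated time of 30 min (a higher number here means that more of the compound is left, a lower number that less of the compound is left), compound 2 gives 10.2%. The other measured analogue, compound 1 `CCCCc1nc(C)c(CC(=O)OC(C)C)c(=O)n1Cc1ccc(-c2ccccc2-c2noc(=O)[nH]2)cc1`, gives 4% in this assay; the step of a number 6.2 percentage points higher from compound 1 to compound 2 (within the scatter) is within the scatter, so the two numbers cannot be told apart. Compound 3 `CCCCc1nc(C)c(CC(=O)OCC(C)C)c(=O)n1Cc1ccc(-c2ccccc2-c2noc(=O)[nH]2)cc1` carries the change (isopropyl in place of propyl on a saturated chain carbon bound to an oxygen next to a carbonyl group); the same atoms of the chain on the oxygen next to a carbonyl group are joined differently. Among the measured compounds shown here, the one measured step bearing on this, from compound 1 to compound 2, also exchanged one alkyl on that oxygen for another and stayed within the scatter, so no step beyond the scatter is expected in this assay for a further exchange of this kind. For compound 3 the expected value is 9%, with a range from 3% to 20%. The expected step of a number 1.2 percentage points lower from compound 2 to compound 3 (within the scatter) is estimated to stay within the scatter.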

Compound 3, percent of the compound remaining: 7.7%
Estimate against measurement, compound 3: 1.3 percentage points above; the range from low to high includes it.
By their numbers in this assay, from the lowest: compounds 1, 3 and 2 (each within the scatter of the next).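

In this assay the rearrangement of the same atoms on the ester oxygen gives a number 2.5 percentage points lower from compound 2 to compound 3 (within the scatter) and so does not separate the straight chain from the branched one. The isobutyl ester compound 3 also compares with the isopropyl ester as a number 3.7 percentage points higher from compound 1 to compound 3 (within the scatter), so the butyl, isobutyl and isopropyl esters of this series cannot be told apart at this position. No measurement at hand accounts for this result.

Going by these compounds, whether any change at this position can move the number beyond the scatter remains open, as the three compounds cover only these saturated alkyl chains. A longer chain or a benzyl group on the oxygen, or an amide or a carboxylic acid in place of the ester, would test this position further.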